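From cyclopentyl to phenyl on an aromatic nitrogen

The source may report more compounds than this note shows. Statements on the series, on what has been measured and on what is new or still open speak of the compounds shown alone.

Compound 1 `CCCN1C(=O)[C@@H](NC(=O)c2cccc(C)c2)[C@@H](c2ccc(F)cc2)c2c1nn(CCC)c2C`: > 25000 nM
Compound 2 `Cc1cccc(C(=O)N[C@@H]2C(=O)Nc3c(c(C)nn3C3CCCC3)[C@@H]2c2ccc(F)cc2)c1`: > 25000 nM
Compound 3 `CCOC1=Nc2c(c(C)nn2-c2ccccc2)[C@H](c2ccc(F)cc2)[C@@H]1NC(=O)c1cccc(C)c1`: > 25000 nM

In an ADME assay on BJ cells (Homo sapiens) for inhibition, read by CellTiter-Glo, with a stated time of 72 h (on this read-out higher numbers stand for an effect only at larger amounts of compound and lower numbers for an effect already at smaller amounts), compound 2 gives > 25000 nM, which is a limit and not a number. The whole set stands at the limit of > 25000 nM in this assay, at which 3 of the 3 values shown sit. Compound 4 `Cc1cccc(C(=O)N[C@@H]2C(=O)Nc3c(c(C)nn3-c3ccccc3)[C@@H]2c2ccc(F)cc2)c1` carries phenyl in place of cyclopentyl on an aromatic nitrogen. Compound 3 also bears phenyl on an aromatic nitrogen and gives > 25000 nM, again a limit. The expected a number no higher from compound 2 to compound 4 (the limit leaves the size open) lies within the scatter of this assay, with no direction foreseen. For compound 4 the estimate is 25000 nM, with an expected range of 12000 nM to 40000 nM.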

Compound 4, half-maximal effective concentration in the BJ assay: > 25000 nM
Compound 4: a limit, no number (the forecaster's own chance of this, stated with the estimate: 85%); the middle value lies on the limit itself.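

In the BJ assay compound 2 gives > 25000 nM, which is a limit and not a number. In the BJ assay compound 4 gives > 25000 nM, again a limit. No step can be read between these two compounds: the limit of > 25000 nM in the BJ assay, at which 4 of the 4 values shown sit. The compounds shown leave open what number, if any, a change on the aromatic nitrogen would give in the BJ assay. In a physicochemical assay for solubility, measured as kinetic solubility, at pH 7.4 (a lower number here means a less soluble compound, a higher number a more soluble compound), compound 2 gives 17100 nM and compound 4 gives 5500 nM. In the physicochemical assay phenyl in place of cyclopentyl on an aromatic nitrogen goes with a 3.1-fold lower number from compound 2 to compound 4 (0.49 log units; beyond the scatter), as measured: the measured solubility of compound 2, 17100 nM, and of compound 4, 5500 nM, a 3.1-fold lower number (0.49 log units; beyond the scatter).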